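A Second Chloro on the Shorter Chain

The compounds below may be only part of what the source reports. "The series", "measured", "known", "first", "only" and "open" are said of these compounds alone.

Of the compounds shown here, two have been measured so far. Compound 2 `O=C(O)CC(O)(CSCCCCCCc1cccc(Cl)c1)C(=O)O` carries a 3-chlorophenyl group at the end of its chain; in an assay on isolated protein for inhibition of ATP-citrate synthase (Rattus norvegicus) (a higher number here means a weaker inhibitor, a lower number a stronger inhibitor), compound 2 gives 150000 nM. Compound 1 `O=C(O)CC(O)(CSCCCCCCCCCc1ccc(Cl)cc1Cl)C(=O)O` bears a dichlorophenyl group on a longer chain, and in this assay compound 1 gives 300000 nM. These two numbers lie within the usual scatter of each other, so nothing can be read from them about how the two compounds differ in this assay.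

Compound 3 `O=C(O)CC(O)(CSCCCCCCc1ccc(Cl)c(Cl)c1)C(=O)O` has not yet been measured. It differs from compound 2 by chloro in place of hydrogen on an aromatic carbon. Among the measured compounds shown here, the only measured compound with two chloro groups on the ring, compound 1, sits on a different chain, so the data give no direct guide to what this change alone does. The step from compound 2 to compound 3 is therefore expected to be small, in either direction, and likely not beyond the scatter. For compound 3 in this assay an inhibition constant of 120000 nM is expected, with a range from 50000 nM to 300000 nM. This estimate corresponds to an expected step of a 1.3-fold lower number from compound 2 to compound 3 (0.10 log units; within the scatter).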

Compound 3, inhibition constant: 110000 nM
For compound 3 the middle estimate is 1.1-fold (0.04 log units) above the measured one, within the range that was stated.
By their numbers in this assay, from the lowest: compounds 3, 2 and 1 (each within the scatter of the next, the first and the last beyond it).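

Chloro in place of hydrogen on the aromatic carbon that is ortho to a chloro group and para to a large group, which turns 3-chlorophenyl into 3,4-dichlorophenyl, gives a 1.4-fold lower number from compound 2 to compound 3 (0.13 log units; within the scatter) in this assay. Among the compounds shown here, this pair is the first that differs in one place only, so the change can now be read directly rather than through compound 1, whose chain and ring both differ: on this chain, the added chloro at this position leaves the two compounds inseparable in this measurement. No measurement on hand speaks to why the added chloro leaves the number within the scatter.

The compounds shown leave open whether another group at this same position, such as a methoxy group, an amine or a carboxylic acid, would move the number beyond the scatter. They also leave open what chain length alone does, since compound 1 differs from compound 2 and compound 3 in more than one place, and a 3,4-dichlorophenyl group on a longer chain would be needed to separate the chain from the ring.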